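Tertiary amine tail swap on the shared core

A few compounds are considered here, and "the series" means these few. Any claim that something is new, unique, unknown or untested is made for them only; others in the source may bear on it.

Measured in an assay on CHO cells for binding affinity to Substance-P receptor (Homo sapiens) (a lower number here means a stronger inhibitor, a higher number a weaker inhibitor), so far:
compound 1 `CCCCCN(CCCCC)C(=O)N1CCN(C(=O)N(c2ccccc2)c2ccccc2)[C@H](CO)C1` — 280 nM
compound 2 `CCCCCN(CCCCC)C(=O)N1CCN(C(=O)N(c2ccccc2)c2ccccc2)[C@H](C(=O)NCC(=O)O)C1` — 597 nM
compound 3 `CCCCCN(CCCCC)C(=O)N1CCN(C(=O)N(c2ccccc2)c2ccccc2)[C@H](C(=O)NCCN(C(C)C)C(C)C)C1` — 217 nM

Compound 3 carries the lowest of the three numbers in this assay, but the step of a 1.3-fold lower number from compound 1 to compound 3 (0.11 log units; within the scatter) lies within the scatter, so compound 3 and compound 1 cannot be ordered. Within the data shown here, only the step of a 2.8-fold lower number from compound 2 to compound 3 (0.44 log units; beyond the scatter) is beyond it, and the step of a 2.1-fold higher number from compound 1 to compound 2 (0.33 log units; beyond the scatter) is of similar modest size in the other direction.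

Compound 4 `CCCCCN(CCCCC)C(=O)N1CCN(C(=O)N(c2ccccc2)c2ccccc2)[C@H](C(=O)NCCCN(CC)CC)C1` differs from compound 3 by (diethylamino)methyl in place of diisopropylamino on a saturated chain carbon, two bonds along the chain from an amide-type nitrogen. Among the measured compounds shown here, no measured step repeats this kind of swap; the nearest precedent is the replacement of carboxy by (diisopropylamino)methyl, which gave the modest step from compound 2 to compound 3. Here one tertiary amine is exchanged for another, with one more saturated chain carbon between the amide-type nitrogen and the amine. A step of no more than the scatter is expected, a 1.2-fold higher number from compound 3 to compound 4 (0.06 log units; within the scatter). Compound 4 is estimated at 250 nM, with a range of 110 nM to 550 nM.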

Compound 4, half-maximal inhibitory concentration: 41 nM
Estimate against measurement, compound 4: 6.1-fold (0.79 log units) above; the measured number lies below the stated range.
By their numbers in this assay, from the lowest: compound 4; then compounds 3 and 1 (each within the scatter of the next); then compound 2.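

In this assay the side chain on this saturated ring carbon proves able to shift the number well beyond the scatter, even when one tertiary amine replaces another: 3-(diethylamino)propyl in place of 2-(diisopropylamino)ethyl gives a 5.3-fold lower number from compound 3 to compound 4 (0.72 log units; beyond the scatter) in this series. Compound 3 could not be ordered against compound 1, but the 3-(diethylamino)propyl tail separates clearly from the hydroxymethyl group, with a 6.8-fold lower number from compound 1 to compound 4 (0.83 log units; beyond the scatter) as the result, and from the carboxy-ended tail, with a 15-fold lower number from compound 2 to compound 4 (1.16 log units; beyond the scatter) as the result. No measured evidence bears on this result.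

As far as these compounds go, the chain length and the groups on the amine change together, so their separate shares stay open. A 2-(diethylamino)ethyl or 3-(diisopropylamino)propyl tail would separate them, and a 4-(diethylamino)butyl tail would test a longer chain.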